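Carbamate Series: Aryl Swap on the Amide Nitrogen

The source may report more compounds than this note shows. Statements on the series, on what has been measured and on what is new or still open speak of the compounds shown alone.

Measured compounds and values:
Compound 1 `CC(C)=CCC/C(C)=C/COc1cc(=O)n(CCCO)c2c1CC(CC=C(C)C)C(C)(C)C2` gives 18.4%.
Compound 2 `CC(C)=CCC1Cc2c(OC(=O)Nc3cccc(F)c3)cc(=O)n(CCCO)c2CC1(C)C` gives 0%.
Compound 3 `CC(C)=CCC1Cc2c(OC(=O)Nc3ccc(F)cc3F)cc(=O)n(CCCO)c2CC1(C)C` gives 0%.

The read-out for all three is a functional assay on PANC-1 cells (Homo sapiens) for inhibition, read by MTT assay, with a stated time of 24 h, tested at 10 uM; on this read-out lower numbers stand for less inhibition and higher numbers for more inhibition at the one concentration tested (going by the name of the read-out). Compound 3 stands level with compound 2 at the digits reported, the two together the lowest of the three numbers; its only gap beyond the scatter is to compound 1, which lies higher by a number 18.4 percentage points lower from compound 1 to compound 3 (beyond the scatter). The carbamate pair itself is flat: no change at the digits printed from compound 2 to compound 3 (within the scatter).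

Compound 4 `CC(C)=CCC1Cc2c(OC(=O)Nc3ccc(Cl)cc3)cc(=O)n(CCCO)c2CC1(C)C` is not yet measured. The change from compound 3 is 4-chlorophenyl in place of 2,4-difluorophenyl on an amide-type nitrogen. For the measured compounds named here, the one measured step that bears on it is the earlier aryl swap on the same amide-type nitrogen, no change at the digits printed from compound 2 to compound 3 (within the scatter), which stayed within the scatter. The steps from compound 1 to the carbamates, a number 18.4 percentage points lower from compound 1 to compound 2 (beyond the scatter) and a number 18.4 percentage points lower from compound 1 to compound 3 (beyond the scatter), concern the oxygen substituent rather than the aryl group and do not bear directly on this change. With one flat precedent, no step beyond the scatter is expected here: compound 4 is estimated at 3%, range 0% to 12%, which means an expected step of a number 3 percentage points higher from compound 3 to compound 4 (within the scatter) in this assay.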

Compound 4, a percentage reported as inhibition, at one concentration (the size of the read-out at that concentration, not a potency): 0%
Beside the measured number, compound 4's estimate is 3 percentage points above it; low and high end bracket the measured number.
By their numbers in this assay, from the lowest: compounds 2, 3 and 4 (each within the scatter of the next); then compound 1.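

In this assay, the aryl group on the amide-type nitrogen now extends beyond fluorinated rings, yet the number holds: no change at the digits printed from compound 3 to compound 4 (within the scatter), and likewise no change at the digits printed from compound 2 to compound 4 (within the scatter), so 4-chlorophenyl reads the same as both 2,4-difluorophenyl and 3-fluorophenyl. The gap to the 3,7-dimethylocta-2,6-dien-1-yl group on the oxygen also persists with a third carbamate, a number 18.4 percentage points lower from compound 1 to compound 4 (beyond the scatter), and no carbamate shown goes against this pattern. No measured evidence accounts for the flat aryl position or for the gap to compound 1.

On these data alone, with all three carbamates at the same printed number, the aryl position shows no spread to work from, and it remains open whether an aryl ring carrying an amine or a carboxylic acid, or a longer alkyl chain in place of the aryl ring, would give a number different from that of compound 4 at 0%. Also open, as far as these compounds go, is whether a shorter chain on the oxygen, such as prenyl, would keep any of the reading of compound 1 at 18.4%.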